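The source may hold more compounds than are shown below. What is called first, only, known or untested is meant among the compounds shown, and "the series" means these compounds.

Working notes on the series. Compound 1 `COc1ccc(S(=O)(=O)Oc2ccccc2/C=C(\C#N)C(=O)Nc2nnc(Cc3ccc(F)cc3)s2)cc1` gives 76% in a functional assay on RS4-11 cells (Homo sapiens) for inhibition, read by CCK-8 assay, with a stated time of 48 h, tested at 20 uM; on this read-out lower numbers stand for less inhibition of growth and higher numbers for more inhibition of growth at the one concentration tested. Compound 2 `COc1ccc(S(=O)(=O)Oc2ccccc2/C=C(\C#N)C(=O)Nc2nnc(Cc3ccc(Cl)cc3)s2)cc1` gives 77% in this assay. The change fluoro in place of chloro on an aromatic carbon made a step of a number 1 percentage points lower from compound 2 to compound 1 (within the scatter). Compound 3 `N#C/C(=C\c1ccccc1OS(=O)(=O)c1ccc(Cl)cc1)C(=O)Nc1nnc(Cc2ccc(Cl)cc2)s1` gives 64% in this assay; it differs from compound 2 by chloro in place of methoxy on an aromatic carbon, a step of a number 13 percentage points lower from compound 2 to compound 3 (beyond the scatter), and that is also how the core of compound 3 and compound 4 differs from the core of compound 1 and compound 2.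

Compound 4 `N#C/C(=C\c1ccccc1OS(=O)(=O)c1ccc(F)cc1)C(=O)Nc1nnc(Cc2ccc(Cl)cc2)s1` is not yet measured. It differs from compound 3 by fluoro in place of chloro on an aromatic carbon. The place reads the same as for the earlier change, but the wider reading differs: 4-chlorobenzyl there, (4-chlorophenyl)sulfonyl here, so it is the same kind of change, not the same. Because the earlier step was a number 1 percentage points lower from compound 2 to compound 1 (within the scatter), the step from compound 3 to compound 4 is expected to be small, about a number 2 percentage points lower from compound 3 to compound 4 (within the scatter). Compound 4 is therefore estimated at 62%, between 50% and 74%.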

Compound 4, percent growth inhibition at one concentration: 64%
Estimate against measurement, compound 4: 2 percentage points below; low and high end bracket the measured number.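

In this assay, fluoro in place of chloro gives no change at the digits printed from compound 3 to compound 4 (within the scatter), whereas fluoro in place of methoxy on that aromatic carbon gives a number 13 percentage points lower from compound 2 to compound 4 (beyond the scatter). Fluoro in place of chloro carries from one core to the other with no step that stands out from the scatter: the same change on two cores in this assay, a number 1 percentage points lower (within the scatter) from compound 2 to compound 1 and no change at the digits printed (within the scatter) from compound 3 to compound 4, 1 percentage points apart, within the scatter of two such steps. Going by these compounds alone, this rests on only two pairs, with the change on the 4-chlorobenzyl group in one and on the (4-chlorophenyl)sulfonyl group in the other, and at one concentration it shows only that the two halogens are not told apart, not that the change would carry to other cores.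

Open, going by these compounds, is how an amine or a carboxylic acid on that aromatic carbon would read. Also open, on these data alone, is whether a fluoro and chloro exchange would read the same beside either group.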